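Swapping chloro for hydrogen on a diaryl urea

A few compounds are considered here, and "the series" means these few. Any claim that something is new, unique, unknown or untested is made for them only; others in the source may bear on it.

Measured so far:
compound 1, `O=C(Nc1ccc(Br)cc1)Nc1cccc(Cl)c1`: 6400 nM
compound 2, `Cc1ccc(NC(=O)Nc2cccc(Cl)c2)cc1C`: "not active" (no number reported)
compound 3, `O=C(Nc1ccccc1)Nc1ccc(Br)cc1`: 6100 nM

In a physicochemical assay for inhibition, with a stated time of 7 days (on this read-out lower numbers stand for stronger inhibition and higher numbers for weaker inhibition), compound 1 gives 6400 nM. Compound 3 carries hydrogen in place of chloro on an aromatic carbon, and the step of a 1.0-fold lower number from compound 1 to compound 3 (0.02 log units; within the scatter) shows that this change made no real difference. Compound 2 is reported in this assay only as "not active" (no number reported), a statement without a number. How the core of compound 2 differs from that of compound 1 is not broken down here. Compound 4, `Cc1ccc(NC(=O)Nc2ccccc2)cc1C`, is the untested partner of compound 2, bearing (hydrogen in place of chloro on an aromatic carbon), the same change as the one made earlier. Since compound 2 gave no number and the same change left compound 1 essentially where it was in a 1.0-fold lower number from compound 1 to compound 3 (0.02 log units; within the scatter), compound 4 is expected to show weak inhibition in this assay, quite possibly again without a reported number. The estimate for compound 4 is 30000 nM, expected to lie between 8000 nM and 100000 nM.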

Compound 4, half-maximal inhibitory concentration: 9000 nM
Compound 4: the middle estimate sits 3.3-fold (0.52 log units) above what was measured; low and high end bracket the measured number.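

No step can be read between compound 2 and compound 4: compound 2 has only the words "not active", with no number. On these data alone, what swapping chloro for hydrogen does on the core of compound 2 stays open. No supporting evidence bears on this result.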